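Adding an isobutyl branch to a glycine ester prodrug

The source may report more compounds than this note shows. Statements on the series, on what has been measured and on what is new or still open speak of the compounds shown alone.

Three compounds share a purine-like core with a cyclopropyl-bearing nitrogen and an acetamide linked to a benzyl ester. Compound 1 `CC(C)[C@H](NC(=O)CN(c1nc(Cl)nc2[nH]cnc12)C1CC1)C(=O)OCc1ccccc1` carries an isopropyl branch on the amino-acid carbon; in a functional assay on the whole organism (Tail, strain ICR) with Mus musculus as the target, in the tail flick test, with a stated time of 60 min, at a dose of 25 umol/kg by the oral route (on this read-out higher numbers stand for a stronger effect at the one dose given and lower numbers for a weaker effect), compound 1 gives 55.5%. Compound 2 `O=C(CN(c1ncnc2c1ncn2C1CCCCO1)C1CC1)NCC(=O)OCc1ccccc1` has a different substituent on the core and no branch on that carbon; in this assay compound 2 gives 40.4%, the second highest of the three numbers. Compound 3 `CC(C)C[C@H](NC(=O)CN(c1nc(Cl)nc2[nH]cnc12)C1CC1)C(=O)OCc1ccccc1` carries an isobutyl branch with the core of compound 1; in this assay compound 3 gives 27.3%.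

Compound 4 `CC(C)C[C@H](NC(=O)CN(c1ncnc2c1ncn2C1CCCCO1)C1CC1)C(=O)OCc1ccccc1` is built from compound 2 by the change (isobutyl in place of hydrogen on a saturated chain carbon bound to an amide-type nitrogen and a carbonyl carbon). Among the compounds with values here, the only measured step that touches this carbon is a number 28.2 percentage points lower from compound 1 to compound 3 (beyond the scatter), where the isobutyl group lowered the number relative to isopropyl. Within the data shown here, no step from hydrogen to isobutyl exists, so the expectation is uncertain, but a moderate decrease is expected, namely a number 10.4 percentage points lower from compound 2 to compound 4 (beyond the scatter). Compound 4 is therefore estimated at 30%, within a range from 10% to 52%.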

Compound 4, a percentage reported as activity, at one dose (the size of the read-out at that dose, not a potency): 34.2%
The estimate for compound 4 lay 4.2 percentage points below the measured number, within the range that was stated.
By their numbers in this assay, from the lowest: compounds 3, 4 and 2 (each within the scatter of the next, the first and the last beyond it); then compound 1.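

In this assay, putting isobutyl in place of hydrogen on a saturated chain carbon bound to an amide-type nitrogen and a carbonyl carbon gives a number 6.2 percentage points lower from compound 2 to compound 4 (within the scatter), so on this core the carbon accepts a branched group of 4 heavy atoms without a change that can be told from scatter. The earlier step, a number 28.2 percentage points lower from compound 1 to compound 3 (beyond the scatter), swapped one branch for another on a different core, so it could not show what a branch does compared with hydrogen. Nothing measured here offers a reason for either result.

Still open, from the compounds shown here alone, is how isopropyl at this carbon would read on the core of compound 2, which would show whether the earlier gap between the branches carries over. Also open, going by these compounds, is how a longer chain, or a chain ending in an amine or a carboxylic acid, would read at this carbon.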